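Ester variant of the thiophene dihydropyrimidinone series

The source may hold more compounds than are shown below. What is called first, only, known or untested is meant among the compounds shown, and "the series" means these compounds.

Measured so far:
Compound 1 `CCCC(=O)C1=C(C)NC(=O)NC1c1ccsc1` gives 9% in an assay on membranes from HEK293 cells for displacement of a labelled ligand from adenosine receptor A2b (Homo sapiens), read by scintillation counting, with a stated time of 30 min, tested at 1 uM; a lower number here means less inhibition, a higher number more inhibition at the concentration tested (going by the name of the read-out).
Compound 2 `CCNC(=O)C1=C(C)NC(=O)NC1c1ccsc1` gives 1%.
Compound 3 `CCN(CC)C(=O)C1=C(C)NC(=O)NC1c1ccsc1` gives 11%.

Compound 3 holds the highest of the three numbers, but its steps to the others are within the scatter: a number 2 percentage points higher from compound 1 to compound 3 (within the scatter) and a number 10 percentage points higher from compound 2 to compound 3 (within the scatter). The step of a number 8 percentage points lower from compound 1 to compound 2 (within the scatter) is likewise within the scatter. All three changes at the carbonyl carbon therefore left the inhibition essentially flat.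

Compound 4 `CCC(CC)OC(=O)C1=C(C)NC(=O)NC1c1ccsc1` differs from compound 3 as follows: (pentan-3-yl)oxy in place of diethylamino on a carbonyl carbon. The nearest precedents are the changes at the same carbonyl carbon just named; none moved the number beyond the scatter, so no step beyond the scatter is expected in this assay here either, a number 3 percentage points lower from compound 3 to compound 4 (within the scatter). Compound 4 is estimated at 8%, with a range of 0% to 25%.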

Compound 4, a percentage reported as inhibition, at one concentration (the size of the read-out at that concentration, not a potency): 26%
Beside the measured number, compound 4's estimate is 18 percentage points below it; the measured number lies above the stated range.
By their numbers in this assay, from the lowest: compounds 2, 1 and 3 (each within the scatter of the next); then compound 4.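

At this carbonyl carbon, in this assay, (pentan-3-yl)oxy is the only group among those shown to move the number beyond the scatter, with a number 15 percentage points higher from compound 3 to compound 4 (beyond the scatter) and a number 25 percentage points higher from compound 2 to compound 4 (beyond the scatter) and a number 17 percentage points higher from compound 1 to compound 4 (beyond the scatter). Propyl, ethylamino and diethylamino stay within the scatter of each other, so the position is not flat for every group, although all three new steps are modest. No available evidence bears on this rise.

From the compounds shown here alone, it remains open whether the step follows the oxygen link or the branched pentan-3-yl chain. Ethoxy or benzyloxy on the same carbonyl carbon would help separate the two.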